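The source may hold more compounds than are shown below. What is called first, only, known or untested is meant among the compounds shown, and "the series" means these compounds.

Compound 2 `Cc1ccnc(/C(N)=N/NC(=S)N2CCCCC2)c1` gives 62.1% in a functional assay on HeLa cells (Homo sapiens) for cytotoxicity, read by MTT assay, with a stated time of 72 h, tested at 10 uM (on this read-out lower numbers stand for less inhibition of growth and higher numbers for more inhibition of growth at the one concentration tested), the higher of the two numbers measured, with compound 1 `Cc1ccnc(/C(N)=N/NC(=S)N2CCOCC2)c1` giving 49.1%. Among the measured compounds shown here, the only measured step, a number 13 percentage points higher from compound 1 to compound 2 (beyond the scatter), is the one that bears on the next change. Compound 3 `Cc1ccnc(/C(N)=N/NC(=S)N2CCCC2)c1` differs from compound 2 by pyrrolidin-1-yl in place of piperidin-1-yl on a thiocarbonyl carbon. For the measured compounds named here, no measured step tells how shortening this ring acts. The step expected here is estimated as a number 7.1 percentage points lower from compound 2 to compound 3 (within the scatter). Compound 3 is estimated at 55%, with a range from 35% to 75%.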

Compound 3, percent growth inhibition at one concentration: 67%
Compound 3: middle estimate off by 12 percentage points, on the low side, within the range that was stated.
By their numbers in this assay, from the lowest: compound 1; then compounds 2 and 3 (each within the scatter of the next).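

In this assay, the change from piperidin-1-yl to pyrrolidin-1-yl on a thiocarbonyl carbon reads as a number 4.9 percentage points higher from compound 2 to compound 3 (within the scatter), so these two rings cannot be told apart here. Morpholin-4-yl gives way to pyrrolidin-1-yl with a number 17.9 percentage points higher from compound 1 to compound 3 (beyond the scatter), which leaves compound 1 apart from both compound 2 and compound 3. Nothing available explains this difference. As far as these compounds go, it remains open whether a larger azepan-1-yl ring, an open-chain dimethylamino group or a 4-methylpiperazin-1-yl group on this carbon would match compound 2 and compound 3 or fall toward compound 1.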